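The source may report more compounds than this note shows. Statements on the series, on what has been measured and on what is new or still open speak of the compounds shown alone.

Three compounds have so far been measured in an assay on isolated protein for inhibition of acyl-CoA desaturase 1 (Rattus norvegicus); on this read-out lower numbers stand for stronger inhibition and higher numbers for weaker inhibition:

Compound 1 `O=C(O)c1cncc(-c2ccc(N3CCC(Oc4ccccc4Br)CC3)nn2)c1` gives 47 nM.
Compound 2 `O=C(O)c1cncc(-c2ccc(N3CCC(Oc4ccccc4I)CC3)nn2)c1` gives 27 nM.
Compound 3 `O=C(O)c1cncc(-c2ccc(N3CCC(Oc4cc(F)c(F)cc4Br)CC3)nn2)c1` gives 15 nM.

Compound 3 stands at the lowest of the three numbers. Against compound 2 the gap is only a 1.8-fold lower number from compound 2 to compound 3 (0.26 log units; within the scatter), so the two cannot be ranked on these numbers; compounds 1 and 2 are likewise separated by no more than a 1.7-fold lower number from compound 1 to compound 2 (0.24 log units; within the scatter). Going by the values given here, the one step that clears the scatter is the one from the 2-bromophenyl of compound 1 to the 2-bromo-4,5-difluorophenyl of compound 3, which reads a 3.1-fold lower number from compound 1 to compound 3 (0.50 log units; beyond the scatter).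

Compound 4 `O=C(O)c1cncc(-c2ccc(N3CCC(Oc4cc(F)ccc4Br)CC3)nn2)c1` has not been measured. It differs from compound 3 in one place: hydrogen in place of fluoro on an aromatic carbon. This is a partial reversal of the change that separates compound 1 from compound 3, in which two fluoro groups entered together; here one of them is taken away again while the other stays. Among the compounds with values here, only that single step bears on the question, and it was modest. The expectation is therefore a small move upward in this assay, likely within the scatter, with compound 4 estimated at 24 nM, between 11 nM and 52 nM, which means an expected step of a 1.6-fold higher number from compound 3 to compound 4 (0.20 log units; within the scatter).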

Compound 4, half-maximal inhibitory concentration: 15 nM
Estimate against measurement, compound 4: 1.6-fold (0.20 log units) above; measured number inside the range.
By their numbers in this assay, from the lowest: compounds 3, 4, 2 and 1 (each within the scatter of the next, the first and the last beyond it).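

In this assay, going by these compounds alone, removing the fluoro that sat para to a large group and meta to a bromo group reads no change at the digits printed from compound 3 to compound 4 (within the scatter) and so costs nothing that can be seen, which the earlier compounds could not show because the two fluoro groups had only appeared together. Within the data shown here, the single fluoro that remains already carries a step of the same printed size as the double change, since the one step reads a 3.1-fold lower number from compound 1 to compound 4 (0.50 log units; beyond the scatter) and the two together read a 3.1-fold lower number from compound 1 to compound 3 (0.50 log units; beyond the scatter) in this pair of comparisons, and the hydrogen at the vacated place is as good as fluoro on these numbers. Compound 4 also cannot be ranked against the iodo analogue, with a 1.8-fold lower number from compound 2 to compound 4 (0.26 log units; within the scatter) on record, and no measurement at hand says why one fluoro can go while the shift from compound 1 stays.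

Still open, from the compounds shown here alone, is whether a lone fluoro at the vacated place, with hydrogen where compound 4 keeps its fluoro, would read the same. Also open, going by these compounds, is whether chloro, methoxy or a nitrile at the retained place would hold the number, and whether iodo in place of bromo adds anything once that fluoro is present.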